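A trifluoromethyl swap on the amide of compound 3

This account rests on a few compounds, and the source may have more. Where it says the series, first, only, none or still open, it means among the compounds named here.

Compound 1 `COC(=O)c1scc(-c2ccc(NC(=O)c3cccc(I)c3)cc2)c1OC`: 14700 nM
Compound 2 `COC(=O)c1scc(-c2ccc(NC(=O)c3cc(I)ccc3F)cc2)c1OC`: 35600 nM
Compound 3 `COC(=O)c1scc(-c2ccc(NC(=O)c3ccc(OC)nc3)cc2)c1OC`: 18300 nM

These values come from a functional assay on K562 cells (Homo sapiens) for antiproliferative activity, read by MTT assay, with a stated time of 24 h (on this read-out higher numbers stand for weaker inhibition and lower numbers for stronger inhibition), and share one core, differing only around the amide. Compound 3 cannot be ranked against either relative: the data show a 1.2-fold higher number from compound 1 to compound 3 (0.10 log units; within the scatter) and also a 1.9-fold lower number from compound 2 to compound 3 (0.29 log units; within the scatter) in this test.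

The next molecule, compound 4 `COC(=O)c1scc(-c2ccc(NC(=O)c3ccc(C(F)(F)F)cc3)cc2)c1OC`, keeps the shared core and changes the group on the carbonyl carbon. It carries 4-(trifluoromethyl)phenyl in place of 6-methoxypyridin-3-yl on a carbonyl carbon.

The two steps just given are the nearest guide, since each exchanges the whole group at this same place, and neither leaves the scatter. Going by the values given here, the only step beyond the scatter is a 2.4-fold higher number from compound 1 to compound 2 (0.38 log units; beyond the scatter), which is modest and comes from fluoro in place of hydrogen on an aromatic carbon. Among the compounds with values here, no measured compound carries a trifluoromethyl group, so the data offer no direction for this change. A step beyond the scatter is therefore not expected in this assay for this exchange. The expected result is a 1.1-fold higher number from compound 3 to compound 4 (0.04 log units; within the scatter), which amounts to no real change. For compound 4 the estimated value is 20000 nM, with an expected range from 9000 nM to 45000 nM as its limits.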

Compound 4, half-maximal inhibitory concentration: 9260 nM
Compound 4: middle estimate off by 2.2-fold (0.33 log units), on the high side, within the range that was stated.
By their numbers in this assay, from the lowest: compounds 4, 1, 3 and 2 (each within the scatter of the next, the first and the last beyond it).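

Going by these compounds alone, exchanging the whole group on the carbonyl carbon now gives a step beyond the scatter for the first time in this assay: replacing 2-fluoro-5-iodophenyl with 4-(trifluoromethyl)phenyl gives a 3.8-fold lower number from compound 2 to compound 4 (0.58 log units; beyond the scatter) and this change is modest in size. The other two exchanges stay within the scatter, with a 2.0-fold lower number from compound 3 to compound 4 (0.30 log units; within the scatter) and a 1.6-fold lower number from compound 1 to compound 4 (0.20 log units; within the scatter) as the printed steps, so a ring with hydrogen-bond acceptors and a ring without them are not told apart by the first of these two comparisons, and replacing iodine-bearing 3-iodophenyl also gives no readable change. Nothing at hand gives a measured reason for any of these differences.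

All the compounds shown keep a six-membered aromatic ring on the carbonyl carbon, so it remains open what a saturated cyclohexyl ring, or an aromatic ring bearing an amine or a carboxylic acid, would do at this place. Trifluoromethyl also appears only in 4-(trifluoromethyl)phenyl, so it is unknown whether a methyl group or a chlorine atom in its stead would give a similar number.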